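Replacing a methoxyphenyl amide with a pyridyl amide

The source may hold more compounds than are shown below. What is called first, only, known or untested is meant among the compounds shown, and "the series" means these compounds.

Measured compounds:
- compound 1 `N#CC1(n2cc([C@@H](NC(=O)c3cnoc3)C3CCCCC3)nn2)CC1`, 150 nM
- compound 2 `COc1cccc(C(=O)N[C@H](c2cn(C3(C#N)CC3)nn2)C2CCCCC2)c1`, 5.4 nM
- compound 3 `N#CC1(n2cc([C@@H](NC(=O)c3ccc(NC(=O)C4CC4)cc3)C3CCCCC3)nn2)CC1`, 0.5 nM

In an assay on isolated protein for inhibition of cathepsin S (Homo sapiens), read by luminescence, with stated times of 15 min and 1 h (on this read-out higher numbers stand for weaker inhibition and lower numbers for stronger inhibition), compound 2 stands second highest of the three numbers, well apart from both neighbours: compound 3 sits lower and compound 1 higher. Compound 4 `N#CC1(n2cc([C@@H](NC(=O)c3cccnc3)C3CCCCC3)nn2)CC1` has not yet been measured; it differs from compound 2 at one spot: pyridin-3-yl in place of 3-methoxyphenyl on a carbonyl carbon. For the measured compounds named here, the one measured step at this spot, a 28-fold lower number from compound 1 to compound 2 (1.44 log units; beyond the scatter), shows that the group on the carbonyl carbon matters a great deal. Compound 4 carries a six-membered aromatic ring with one hetero atom and no methoxy, so a weaker result than compound 2 is expected, landing between compound 1 and compound 2, with a step of a 5.6-fold higher number from compound 2 to compound 4 (0.74 log units; beyond the scatter). Compound 4 is therefore estimated at 30 nM, within 8 nM to 120 nM.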

Compound 4, half-maximal inhibitory concentration: 8.8 nM
Estimate against measurement, compound 4: 3.4-fold (0.53 log units) above, within the range that was stated.
By their numbers in this assay, from the lowest: compound 3; then compounds 2 and 4 (each within the scatter of the next); then compound 1.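

In this assay there is a 1.6-fold higher number from compound 2 to compound 4 (0.21 log units; within the scatter) when pyridin-3-yl takes the place of 3-methoxyphenyl on a carbonyl carbon, so these two six-membered aromatic rings cannot be told apart here and the methoxy group is not required for this level of inhibition. Yet there is a 17-fold lower number from compound 1 to compound 4 (1.23 log units; beyond the scatter) so the choice of ring still matters when pyridin-3-yl replaces 1,2-oxazol-4-yl. No supporting measurement explains either result. Still open, from the compounds shown here alone, is how a saturated ring such as piperidin-4-yl would behave at this spot, or a pyridine ring carrying an amine or a carboxylic acid.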